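Chloro for fluoro on the urea-bearing phenyl ring

The source may hold more compounds than are shown below. What is called first, only, known or untested is meant among the compounds shown, and "the series" means these compounds.

Measured compounds:
compound 1, `CN(C)CCNc1nc(-c2ccc(NC(=O)Nc3ccc(Cl)cc3)cc2)nc2c(Cl)c(Cl)sc12`, 460 nM
compound 2, `CCN(CC)CCCNc1nc(-c2ccc(NC(=O)Nc3ccc(F)cc3)cc2)nc2c(Cl)c(Cl)sc12`, 350 nM

Of the compounds shown here, two have been measured in a functional assay on HT-29 cells (Homo sapiens) for cytotoxicity, read by MTT assay, with a stated time of 72 h; on this read-out higher numbers stand for weaker inhibition and lower numbers for stronger inhibition. Compound 1 gives 460 nM, and compound 2 gives 350 nM. Of the two numbers, compound 2 has the lower one, but its nearest neighbour, compound 1, lies within the scatter of it, so the two values cannot be told apart.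

Compound 3, `CCN(CC)CCCNc1nc(-c2ccc(NC(=O)Nc3ccc(Cl)cc3)cc2)nc2c(Cl)c(Cl)sc12`, has not yet been measured. It differs from compound 2 in one place: chloro in place of fluoro on an aromatic carbon, para to a large group. Going by the values given here, no pair of measured compounds shows this change alone, so its size in this assay is unknown. Compound 1 already carries the chloro group on the same ring and gives a value close to that of compound 2, which gives no hint of a step beyond the scatter in either direction.

Compound 3 is therefore expected to give about 380 nM, with a range of 180 nM to 800 nM. This estimate means a step of a 1.1-fold higher number from compound 2 to compound 3 (0.04 log units; within the scatter) that is expected to stay within the scatter.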

Compound 3, half-maximal inhibitory concentration: 250 nM
Compound 3: the middle estimate sits 1.5-fold (0.18 log units) above what was measured, and the stated range covers the measured number.
By their numbers in this assay, from the lowest: compounds 3, 2 and 1 (each within the scatter of the next).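

Going by these compounds alone, compound 3 gives the first reading of this change alone: in this assay, going from 4-fluorophenyl to 4-chlorophenyl on the urea gives a 1.4-fold lower number from compound 2 to compound 3 (0.15 log units; within the scatter) and so does not separate the two halogens at this place, para to a large group. Within the data shown here, it also gives the first single-place comparison on the amine-bearing side chain, where (diethylamino)methyl in place of dimethylamino gives a 1.8-fold lower number from compound 1 to compound 3 (0.26 log units; within the scatter) with the 4-chlorophenyl group held constant, so neither of the two single changes now on record moves the number beyond what repeated measurements would show. No measurement among these data speaks to the reason for either step.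

The compounds shown leave open whether a group of another kind on this ring, such as methoxy, trifluoromethyl or a nitrile, or a bare phenyl ring with no halogen at all, would produce a step that could be read beyond the scatter. They also leave open how the number would respond if the diethylamino end of the chain gave way to a morpholine, a carboxylic acid or a longer chain.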